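Lengthening the Ester Chain of Compound 1

This account rests on a few compounds, and the source may have more. Where it says the series, first, only, none or still open, it means among the compounds named here.

Compound 1 `CC(=O)OCc1ccc2oc(=O)c(C(=O)Oc3cccc(Br)c3)cc2c1` was tested in a functional assay on HT-1080 cells (Homo sapiens), read by transwell migration, with a stated time of 24 h, tested at 10 uM (a higher number here means a weaker effect of the compound at the concentration tested, a lower number a stronger effect), where compound 1 gives 11.8%, the lowest of the two numbers available. Among the compounds with values here, its only measured neighbour is compound 2 `CC(=O)OCc1ccc2oc(=O)c(C(=O)Sc3cccc(Br)c3)cc2c1`, and in this assay compound 2 gives 67.8%. Within the data shown here, the step of a number 56 percentage points higher from compound 1 to compound 2 (beyond the scatter) is the one change recorded so far, and it concerns the (3-bromophenyl)sulfanyl group that replaces 3-bromophenoxy on a carbonyl carbon.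

Compound 3 `CCCCCC(=O)OCc1ccc2oc(=O)c(C(=O)Oc3cccc(Br)c3)cc2c1` has not yet been measured. It differs from compound 1 by butyl in place of hydrogen on a saturated chain carbon bound to a carbonyl carbon. Among the measured compounds shown here, the single measured step alters a different part of the molecule and so offers no direct guide to this change; no measured pair in the set varies the acetyl group at all. With nothing to indicate a shift in either direction, the expectation for compound 3 is a step of a number 8.2 percentage points higher from compound 1 to compound 3 (within the scatter) that stays close to the value of compound 1, with a moderate allowance for a weaker effect. Compound 3 is therefore estimated at 20%, within a range from 6% to 48%.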

Compound 3, a percentage reported as activity, at one concentration (the size of the read-out at that concentration, not a potency): 33.9%
Compound 3: the middle estimate sits 13.9 percentage points below what was measured, and the stated range covers the measured number.
By their numbers in this assay, from the lowest: compound 1; then compound 3; then compound 2.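

The change from acetyl to pentylcarbonyl gives a number 22.1 percentage points higher from compound 1 to compound 3 (beyond the scatter) in this assay, the first sign that this end of compound 1 is not indifferent to change and that the longer chain weakens the effect at the concentration tested. The effect is reduced rather than lost, since the step is modest, while the replacement of 3-bromophenoxy by (3-bromophenyl)sulfanyl, a number 56 percentage points higher from compound 1 to compound 2 (beyond the scatter), is large. Nothing available bears on what lies behind the step caused by adding butyl at this position.

The compounds shown leave open whether the number rises steadily with chain length or whether the change is specific to pentylcarbonyl, as they include neither a propyl nor an octyl chain in its place. They also leave open how a branched tert-butyl group, a phenyl ring, an amine or a carboxylic acid at this position would compare with the acetyl group of compound 1, and whether the same lengthening would have a similar result with (3-bromophenyl)sulfanyl in place of 3-bromophenoxy.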